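Methylpyrazole Amide in Place of the Lactam

This account rests on a few compounds, and the source may have more. Where it says the series, first, only, none or still open, it means among the compounds named here.

Compound 2 `CC1(C)Cc2c(sc(NC(=O)C3CCNC3=O)c2C(N)=O)C(C)(C)O1` gives 101 nM in an assay on cells for positive allosteric modulation of Cystic fibrosis transmembrane conductance regulator variant F508del (Homo sapiens), with stated times of 10 min and 7 s, in the presence of a further agent that is not named here (on this read-out higher numbers stand for an effect only at larger amounts of compound and lower numbers for an effect already at smaller amounts), the higher of the two numbers shown. Compound 1 `CC1(C)Cc2c(sc(NC(=O)c3ccccc3O)c2C(N)=O)C(C)(C)O1` gives 4 nM, so that a 25-fold higher number from compound 1 to compound 2 (1.40 log units; beyond the scatter). Compound 3 `CC1(C)Cc2c(sc(NC(=O)C3CNC(=O)C3)c2C(N)=O)C(C)(C)O1` reaches only a limit in this assay, > 10000 nM, (the limit of > 10000 nM in this assay, at which 1 of the 3 values shown sits). Accordingly an at least 99-fold higher number from compound 2 to compound 3 (1.99 log units; beyond the scatter) is also given as a limit. Compound 4 `Cc1cc(C(=O)Nc2sc3c(c2C(N)=O)CC(C)(C)OC3(C)C)[nH]n1` carries 3-methyl-1H-pyrazol-5-yl in place of 2-oxopyrrolidin-3-yl on a carbonyl carbon. For the measured compounds named here, no measured step involves a 3-methyl-1H-pyrazol-5-yl group; the measured steps show only that exchanging the group on the carbonyl carbon moves this read-out by large amounts in either direction. Compound 4 is expected to give 30 nM, with a range from 4 nM to 400 nM. The step of a 3.4-fold lower number from compound 2 to compound 4 (0.53 log units; beyond the scatter) is thus estimated as a modest move toward lower numbers, with wide uncertainty.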

Compound 4, half-maximal effective concentration: 13 nM
Compound 4: the middle estimate sits 2.3-fold (0.36 log units) above what was measured, within the range that was stated.
By their numbers in this assay, from the lowest: compound 1; then compound 4; then compound 2. At a limit, above all of these: compound 3.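

In this assay, an aromatic five-membered ring can stand on the carbonyl carbon in place of the non-aromatic lactam ring of equal heavy-atom count, with a 7.8-fold lower number from compound 2 to compound 4 (0.89 log units; beyond the scatter). The 2-hydroxyphenyl group still gives the lower number, with a 3.3-fold higher number from compound 1 to compound 4 (0.51 log units; beyond the scatter). The remaining step, an at least 760-fold lower number from compound 3 to compound 4 (2.88 log units; beyond the scatter), is only a limit, set by compound 3: the limit of > 10000 nM in this assay, at which 1 of the 4 values shown sits.

The compounds shown leave open what the methyl on the pyrazole contributes. They also leave open whether a hydrogen or an ethyl group there would give a lower or a higher number.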